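The source may report more compounds than this note shows. Statements on the series, on what has been measured and on what is new or still open speak of the compounds shown alone.

Compound 1, `COC[C@H](NC1CCN(CCCc2c[nH]c3ccc(Cn4cncn4)cc23)CC1)c1ccc(F)cc1`: 5 nM
Compound 2, `c1ccc(C2CCCCN2C2CCN(CCCc3c[nH]c4ccc(-n5cnnc5)cc34)CC2)cc1`: 1.9 nM
Compound 3, `CN(CC1CCN(CCCc2c[nH]c3ccc(-n4cnnc4)cc23)CC1)C(=O)Nc1ccccc1`: 5.9 nM

All three were tested in an assay on CHO cells for displacement of a labelled ligand from 5-hydroxytryptamine receptor 1D (Homo sapiens); a lower number here means a stronger inhibitor, a higher number a weaker inhibitor. Compound 1 gives 5 nM, the second highest of the three numbers. Compound 3, at 5.9 nM, lies within the scatter of compound 1, so the two cannot be told apart. Compound 2, at 1.9 nM, sits beyond the scatter on the lower side, a stronger inhibitor than compound 1.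

The new compound 4, `OC[C@H](NC1CCN(CCCc2c[nH]c3ccc(Cn4cncn4)cc23)CC1)c1ccccc1`, shares the core of compound 1 and differs in one place:

2-hydroxy-1-phenylethyl in place of 1-(4-fluorophenyl)-2-methoxyethyl on an amine nitrogen

Among the measured compounds shown here, no pair of measured compounds differing in one place is available, so there is no measured step to lean on. The change leaves the core untouched and keeps one six-membered aromatic ring of carbon only in the same place, so the expected step from compound 1 to compound 4 is small, a 1.4-fold higher number from compound 1 to compound 4 (0.15 log units; within the scatter), not clearly beyond the scatter and, if anything, toward a slightly higher number. Compound 4 is therefore estimated at 7 nM in this assay, with a range from 2 nM to 25 nM.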

Compound 4, half-maximal inhibitory concentration: 23 nM
Compound 4: middle estimate off by 3.3-fold (0.52 log units), on the low side; measured number inside the range.
By their numbers in this assay, from the lowest: compound 2; then compounds 1 and 3 (each within the scatter of the next); then compound 4.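

In this assay, among the compounds shown here, placing 2-hydroxy-1-phenylethyl on the amine nitrogen instead of 1-(4-fluorophenyl)-2-methoxyethyl gives a 4.6-fold higher number from compound 1 to compound 4 (0.66 log units; beyond the scatter), the first readable step in this set, and it shows that the number responds to this group even with the shared core unchanged. The change is a double one, since the ring fluorine goes and the methoxy end becomes a hydroxyl, which adds a hydrogen-bond donor, so the step cannot be divided between the two edits. Nothing measured here explains the step.

Which edit carries the step remains open, and the two single-edit groups, 1-(4-fluorophenyl)-2-hydroxyethyl and 2-methoxy-1-phenylethyl, would separate them. Also open, on these data alone, is how this position would respond to a different end on the chain, such as the amine in 2-amino-1-phenylethyl.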